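Working notes on the amide variation toward compound 4

A few compounds are considered here, and "the series" means these few. Any claim that something is new, unique, unknown or untested is made for them only; others in the source may bear on it.

Measured so far in a functional assay on MIA PaCa-2 cells (Homo sapiens) for inhibition, read by MTT assay, with a stated time of 7 days; a higher number here means a weaker inhibitor, a lower number a stronger inhibitor:
compound 1 `CCN(CC)S(=O)(=O)c1ccc(S(=O)(=O)N2CCC[C@@H](C(=O)N3CCC(O)CC3)C2)cc1` gives 870 nM
compound 2 `CCN(CC)S(=O)(=O)c1ccc(S(=O)(=O)N2CCC[C@@H](C(=O)NC3CCOCC3)C2)cc1` gives 3770 nM
compound 3 `CCN(CC)S(=O)(=O)c1ccc(S(=O)(=O)N2CCC[C@@H](C(=O)N3CCC(C(F)(F)F)CC3)C2)cc1` gives 320 nM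

Compound 3 gives the lowest number of the three: a 2.7-fold lower number from compound 1 to compound 3 (0.43 log units; beyond the scatter), and a 12-fold lower number from compound 2 to compound 3 (1.07 log units; beyond the scatter). Compound 4 `CCN(CC)S(=O)(=O)c1ccc(S(=O)(=O)N2CCC[C@@H](C(=O)N3CC[C@@H](OC)C3)C2)cc1` differs from compound 3 by 3-methoxypyrrolidin-1-yl in place of 4-(trifluoromethyl)piperidin-1-yl on a carbonyl carbon. Both steps bear on this change, as both alter the group on the carbonyl carbon, and both were beyond the scatter, the cyclic amide of compound 1 coming nearer to compound 3 than the open amide of compound 2. A cyclic amide is kept here, so a modest rise in this assay is expected for compound 4, as a 2.5-fold higher number from compound 3 to compound 4 (0.40 log units; beyond the scatter). Compound 4 is estimated at 800 nM, with a range of 300 nM to 2200 nM.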

Compound 4, half-maximal inhibitory concentration: 3910 nM
The estimate for compound 4 lay 4.9-fold (0.69 log units) below the measured number; measured number outside the range, above it.
By their numbers in this assay, from the lowest: compound 3; then compound 1; then compounds 2 and 4 (each within the scatter of the next).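

In this assay, a cyclic amide on the carbonyl carbon does not by itself keep the number low: 3-methoxypyrrolidin-1-yl gives a 12-fold higher number from compound 3 to compound 4 (1.09 log units; beyond the scatter) and a 4.5-fold higher number from compound 1 to compound 4 (0.65 log units; beyond the scatter). Cyclic or open form does not separate every pair either, with a 1.0-fold higher number from compound 2 to compound 4 (0.02 log units; within the scatter). Nothing at hand accounts for these steps.

Ring size and ring substituent change together in the step to compound 4, and the compounds shown do not separate the two. As far as these compounds go, how a pyrrolidine ring carrying trifluoromethyl, or a piperidine ring carrying methoxy, would read stays open.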